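Methyl for methoxy on a low-toxicity scaffold

A few compounds are considered here, and "the series" means these few. Any claim that something is new, unique, unknown or untested is made for them only; others in the source may bear on it.

Measured compounds:
- compound 1 `COc1cc(O)c(C(=O)O)c(CCc2ccc3ccccc3c2)c1` gives 71000 nM
- compound 2 `CCN(CC)C(=O)c1c(/C=C\c2ccc3ccccc3c2)cc(OC)cc1OC` gives > 100000 nM, a limit
- compound 3 `O=C(O)c1c(O)cccc1/C=C/c1ccccc1` gives > 100000 nM, a limit

Among the measured compounds shown here, in an ADME assay on HepG2 cells (Homo sapiens) for cytotoxicity, read by resazurin assay, with a stated time of 24 h (on this read-out higher numbers stand for lower toxicity in this test and lower numbers for higher toxicity in this test), compound 1 is the only compound with a number. Compounds 2 and 3 both sit at the limit of > 100000 nM in this assay, at which 2 of the 3 values shown sit. Compound 4 `Cc1cc(O)c(C(=O)O)c(CCc2ccc3ccccc3c2)c1` differs from compound 1 in one place: methyl in place of methoxy on an aromatic carbon. For the measured compounds named here, no step between measured compounds is available to weigh this change, and the structures themselves carry no evidence on its effect. The step from compound 1 to compound 4 is therefore expected to be a 1.0-fold lower number from compound 1 to compound 4 (0.01 log units; within the scatter), nothing beyond the scatter, in either direction. Compound 4 is estimated at 70000 nM in this assay, ranging from 30000 nM to 150000 nM.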

Compound 4, half-maximal cytotoxic concentration: 38000 nM
For compound 4 the middle estimate is 1.8-fold (0.27 log units) above the measured one; the measured number falls inside the stated range.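

In this assay, among the compounds shown here, methyl in place of methoxy para to a carboxy group gives a 1.9-fold lower number from compound 1 to compound 4 (0.27 log units; within the scatter), the only step that can be read at this position. On this evidence, the change does not move the number beyond the scatter. Compound 2 and compound 3 offer no number for such a comparison, and each stands at a limit: the limit of > 100000 nM in this assay, at which 2 of the 4 values shown sit.

From the compounds shown here alone, whether an amine, a chloro group or a longer chain at this position would leave the number similarly unmoved remains open. So does the effect of replacing the hydroxy group on the same core.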